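Working notes: from compound 3 to compound 4

The source may report more compounds than this note shows. Statements on the series, on what has been measured and on what is new or still open speak of the compounds shown alone.

- Compound 1 `Cc1cc2c(cc1C)C(Cl)=C(C(=O)NNC(=S)Nc1ccccc1)CCC2`: 759 nM
- Compound 2 `ClC1=C(c2nnc(Nc3ccccc3)s2)CCCc2ccccc21`: 2350 nM
- Compound 3 `Cc1cc2c(cc1C)C(Cl)=C(c1nnc(-c3ccccc3)o1)CCC2`: 1960 nM

All three values come from a functional assay on A549 cells (Homo sapiens) for antiproliferative activity, read by sulforhodamine B assay, with a stated time of 48 h; on this read-out higher numbers stand for weaker inhibition of growth and lower numbers for stronger inhibition of growth. There, compound 3 at 1960 nM lies within the scatter of compound 2 at 2350 nM, while compound 1 at 759 nM gives a lower number, beyond the scatter.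

Compound 4 `Cc1ccc(-c2nnc(C3=C(Cl)c4cc(C)c(C)cc4CCC3)o2)cc1` differs from compound 3 by methyl in place of hydrogen on an aromatic carbon: phenyl to 4-methylphenyl. Among the measured compounds shown here, no measured pair shows this change, so the data offer no direct guide. No shift beyond the scatter is expected in this assay. The estimated step is a 1.1-fold lower number from compound 3 to compound 4 (0.04 log units; within the scatter). For compound 4 the expected value is 1800 nM, with an estimated range of 800 nM to 4000 nM.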

Compound 4, concentration for 50% growth inhibition: 2470 nM
Compound 4: middle estimate off by 1.4-fold (0.14 log units), on the low side; the measured number falls inside the stated range.
By their numbers in this assay, from the lowest: compound 1; then compounds 3, 2 and 4 (each within the scatter of the next).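

In this assay, among the compounds shown here, the first measured pair for phenyl to 4-methylphenyl gives a 1.3-fold higher number from compound 3 to compound 4 (0.10 log units; within the scatter). This position, para to a large group, therefore accepts a methyl without a step beyond the scatter. No available evidence accounts for the size of this step.

On these data alone, whether a larger change at this place, such as an amine or a carboxylic acid, would give a step beyond the scatter remains open. So does whether the same methyl change would give a similar step on the phenyl ring of compound 1.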